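This account rests on a few compounds, and the source may have more. Where it says the series, first, only, none or still open, it means among the compounds named here.

Of the compounds shown here, three of one family have been measured, all carrying the same chain-bearing core and differing only in the group attached to the five-membered aromatic ring with four nitrogen atoms. In an assay on microsomes from brain for inhibition of Fatty-acid amide hydrolase 1 (Rattus norvegicus), read by fluorescence and HPLC, with a stated time of 60 min (a lower number here means a stronger inhibitor, a higher number a weaker inhibitor), compound 1 `CCCCCCCCc1ccc(OCC(=O)Cn2nnc(-c3cccc(S(=O)(=O)N(C)C)c3)n2)cc1` gives 420 nM. Among the measured compounds shown here, compound 2 `CCCCCCCCc1ccc(OCC(=O)Cn2nnc(-c3cccs3)n2)cc1` gives 32 nM, and the single measured step, a 13-fold lower number from compound 1 to compound 2 (1.12 log units; beyond the scatter), shows how strongly this one group can shift the result. Compound 3 `CCCCCCCCc1ccc(OCC(=O)Cn2nnnc2-c2ccc(Cl)cc2)cc1` gives 130 nM and stands second highest of the three numbers: compound 1 sits above it and compound 2 below it, both separated from it by more than the usual scatter.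

Compound 4 `CCCCCCCCc1ccc(OCC(=O)Cn2nnnc2C(=O)OCC)cc1` has not yet been measured. Relative to compound 3 the change is ethoxycarbonyl in place of 4-chlorophenyl on an aromatic carbon. For the measured compounds named here, the only measured step exchanges one aromatic group for another aromatic group, whereas here an ester replaces an aromatic ring entirely, so no measured step bears directly on this change; it shows only that groups at this position can move the number a great deal. With that uncertainty, compound 4 is expected to lie in the weaker part of the observed range, estimated at 300 nM, within 60 nM to 1500 nM. The step this implies, a 2.3-fold higher number from compound 3 to compound 4 (0.36 log units; beyond the scatter), is an expectation rather than a measurement.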

Compound 4, half-maximal inhibitory concentration: 940 nM
Estimate against measurement, compound 4: 3.1-fold (0.50 log units) below, within the range that was stated.
By their numbers in this assay, from the lowest: compound 2; then compound 3; then compound 1; then compound 4.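

In this assay, ethoxycarbonyl in place of 4-chlorophenyl gives a 7.2-fold higher number from compound 3 to compound 4 (0.86 log units; beyond the scatter), so this exchange weakens inhibition by more than the usual scatter. The earlier step exchanged one aromatic group for another, whereas this one shows what happens when a group with no ring takes the place of an aromatic ring on this carbon, between two ring nitrogen atoms. Several things change together, however: the entering group has no ring, has fewer heavy atoms, and brings a double bond outside aromatic rings and hydrogen-bond acceptors, and this single step cannot show which of these differences accounts for the result.

No measurement shown here offers an explanation for the weaker inhibition. As far as these compounds go, it remains open whether losing the ring or adding the ester matters more: a plain ethyl chain, a carboxylic acid or a primary amide on the same carbon would help separate these, while an unsubstituted phenyl would show what the chlorine contributes to compound 3.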